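Bromo in place of fluoro: working notes on compound 3

The compounds below may be only part of what the source reports. "The series", "measured", "known", "first", "only" and "open" are said of these compounds alone.

In a functional assay on MCF7 cells (Homo sapiens) for antiproliferative activity, read by MTT assay, with a stated time of 48 h (on this read-out higher numbers stand for weaker inhibition and lower numbers for stronger inhibition), compound 1 `O=C(NS(=O)(=O)c1ccccc1)c1ccc(Cl)nc1` gives 14100 nM. Compound 2 `O=C(NS(=O)(=O)c1ccc(F)cc1)c1ccc(Cl)nc1` gives 16800 nM, which lies within the scatter of compound 1, so neither number stands apart. Compound 3 `O=C(NS(=O)(=O)c1ccc(Br)cc1)c1ccc(Cl)nc1` has not yet been measured. Its difference from compound 2 is bromo in place of fluoro on an aromatic carbon, para to a large group.

For the measured compounds named here, only one measured step bears on this change: a 1.2-fold higher number from compound 1 to compound 2 (0.08 log units; within the scatter), for fluoro in place of hydrogen on an aromatic carbon. That step stays within the scatter. Going by the values given here, no measured compound carries bromo, so this evidence is thin and the range is kept wide. No step beyond the scatter is expected in this assay. The expected step is a 1.2-fold lower number from compound 2 to compound 3 (0.08 log units; within the scatter). For compound 3 the estimated value is 14000 nM, with an expected range of 7000 nM to 28000 nM.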

Compound 3, half-maximal inhibitory concentration: 9050 nM
Compound 3: middle estimate off by 1.5-fold (0.19 log units), on the high side; the measured number falls inside the stated range.
By their numbers in this assay, from the lowest: compounds 3, 1 and 2 (each within the scatter of the next).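

In this assay the position para to a large group has now carried hydrogen, fluoro and bromo, and the three compounds lie within the scatter of one another. Bromo in place of fluoro gives a 1.9-fold lower number from compound 2 to compound 3 (0.27 log units; within the scatter) and bromo in place of hydrogen gives a 1.6-fold lower number from compound 1 to compound 3 (0.19 log units; within the scatter), so neither exchange separates from the scatter, and this assay draws no distinction among these three groups at this position. No measurement available here speaks to the reason for these small steps.

On these data alone, whether a group of another kind at this position, such as an amine, a methoxy group or a carboxylic acid, would move the number beyond the scatter remains open. Also open, as far as these compounds go, is whether bromo would behave the same way with a change elsewhere on the shared core.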